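The source may report more compounds than this note shows. Statements on the series, on what has been measured and on what is new or still open speak of the compounds shown alone.

Measured in an ADME assay on HCT-116 cells (Homo sapiens) for cytotoxicity, read by CellTiter-Glo, with a stated time of 72 h; on this read-out higher numbers stand for weaker inhibition and lower numbers for stronger inhibition:
- compound 1 `CC1CCN(C2CCN(S(=O)(=O)c3ccc(C#N)cc3)CC2)CC1`: > 5000 nM, a limit
- compound 2 `CC1CCN(C2CCN(S(=O)(=O)c3cn(C)cn3)CC2)CC1`: > 10000 nM, a limit
- compound 3 `CC1CCN(C2CCN(S(=O)(=O)c3cccc(Br)c3)CC2)CC1`: > 5000 nM, a limit

In this assay compound 3 gives > 5000 nM, which is a limit and not a number. The same holds for all three measured compounds, which sit at the limit of > 10000 nM in this assay, at which 1 of the 3 values shown sits, and at the limit of > 5000 nM in this assay, at which 2 of the 3 values shown sit.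

The next compound is compound 4 `CC1CCN(C2CCN(S(=O)(=O)c3ccc(F)cc3F)CC2)CC1`, and the change is 2,4-difluorophenyl in place of 3-bromophenyl on a sulfonyl sulfur. In words, 2,4-difluorophenyl takes the place of 3-bromophenyl on a sulfonyl sulfur, while the shared core stays the same.

Three measured steps change the group at this same place: a step that the two limits leave unreadable from compound 1 to compound 3, a step that the two limits leave unreadable from compound 2 to compound 3 and a step that the two limits leave unreadable from compound 1 to compound 2. None of them has a size that can be read, so they offer no measured effect to carry over to the new group. Going by a step that the two limits leave unreadable from compound 1 to compound 3, no step beyond the usual scatter is expected in either direction, and compound 4 will probably also be reported only as a limit.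

The estimated change is a step that the limit leaves unreadable from compound 3 to compound 4. If a number is obtained, the estimate for compound 4 is 8000 nM, with an expected range from 3000 nM to 20000 nM.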

Compound 4, half-maximal inhibitory concentration: > 5000 nM
Compound 4: no number, only a limit (the forecaster's own chance of this, stated with the estimate: 85%); the middle value lies beyond the limit too.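

In this assay compound 4 gives > 5000 nM, which is a limit and not a number. Compound 1, compound 2 and compound 3 also carry only limits, and none of their steps to compound 4 can be read. The compounds shown leave open whether any group on the sulfonyl sulfur changes the result in this assay, and by how much.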